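The compounds below may be only part of what the source reports. "The series", "measured", "known", "first", "only" and "open" are said of these compounds alone.

Working notes on the series.

Compound 1 `ClCc1ccccc1Cn1cnc2c(Cl)nc(Cl)nc21` and compound 2 `ClCc1ccccc1Cn1cnc2c(Cl)ncnc21` share one core; compound 3 `ClCc1ccc(Cn2cnc3nc(Cl)nc(Cl)c32)cc1` and compound 4 `ClCc1ccc(Cn2cnc3ncnc(Cl)c32)cc1` share another. The difference between the two cores is not broken down here. In a functional assay on NCI-H460 cells (Homo sapiens) for cytotoxicity, read by sulforhodamine B assay, with a stated time of 48 h (on this read-out higher numbers stand for weaker inhibition of growth and lower numbers for stronger inhibition of growth), compound 1 gives 8710 nM, compound 2 gives 44700 nM, and compound 3 gives 35500 nM. Compound 3 and compound 2 lie within the scatter of each other.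

The change from compound 1 to compound 2 is hydrogen in place of chloro on an aromatic carbon, and it made a 5.1-fold higher number from compound 1 to compound 2 (0.71 log units; beyond the scatter). The change from compound 3 to compound 4 is hydrogen in place of chloro on an aromatic carbon, the same change at the same place, made twice in all among these compounds.

Among the measured compounds shown here, for compound 4 in this assay a step of a 4.2-fold higher number from compound 3 to compound 4 (0.63 log units; beyond the scatter) is expected, resting on the single earlier instance a 5.1-fold higher number from compound 1 to compound 2 (0.71 log units; beyond the scatter). The starting point of that step is compound 3, which gives 35500 nM. Compound 4 is estimated at 150000 nM, expected between 50000 nM and 400000 nM.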

Compound 4, concentration for total growth inhibition: 4260 nM
Compound 4: middle estimate off by 35-fold (1.55 log units), on the high side; the whole stated range lies above it.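

In this assay, hydrogen in place of chloro on an aromatic carbon made an 8.3-fold lower number from compound 3 to compound 4 (0.92 log units; beyond the scatter). Among the compounds shown here, the step seen on one core therefore does not carry over to the other, and the direction reverses: the same change on two cores in this assay, a 5.1-fold higher number (0.71 log units; beyond the scatter) from compound 1 to compound 2 and an 8.3-fold lower number (0.92 log units; beyond the scatter) from compound 3 to compound 4, 43-fold (1.63 log units) apart, beyond the scatter of two such steps With only two pairs, this shows that the outcome of the change differs on these two cores, but it does not show which feature of the cores accounts for the difference or how the change would behave on a further core.

Open, as far as these compounds go, is whether an amine or a methoxy group on the same aromatic carbon would also give opposite steps on the two cores. Also open, from the compounds shown here alone, is how a longer chain in place of the chloromethyl group would affect either core.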